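This account rests on a few compounds, and the source may have more. Where it says the series, first, only, none or still open, it means among the compounds named here.

Of the compounds shown here, three built on one shared core have been tested in a functional assay on SK-MEL-28 cells (Homo sapiens) for cytotoxicity, read by MTT assay; a higher number here means a weaker inhibitor, a lower number a stronger inhibitor. Compound 1 `COc1ccc(S(=O)(=O)NCCCNc2nccc(-c3c(-c4cccc(F)c4)nc4sccn34)n2)cc1` carries a methoxy group on the aromatic ring of its sulfonamide and gives 8980 nM. Compound 2 `O=S(=O)(NCCCNc1nccc(-c2c(-c3cccc(F)c3)nc3sccn23)n1)c1ccc(C(F)(F)F)cc1` carries a trifluoromethyl group in that place and gives 11700 nM. Compound 3 `O=S(=O)(NCCNc1nccc(-c2c(-c3cccc(F)c3)nc3sccn23)n1)c1ccc(C(F)(F)F)cc1` keeps the trifluoromethyl group but has a shorter chain linking the sulfonamide to the shared core, and gives 8450 nM. Compound 2 has the highest of these three numbers, yet its gaps to compound 1 and to compound 3 both lie within the usual scatter of this kind of measurement, so the three cannot be told apart on these data.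

Compound 4 `Cc1ccc(S(=O)(=O)NCCCNc2nccc(-c3c(-c4cccc(F)c4)nc4sccn34)n2)cc1` is compound 2 with a single change: methyl in place of trifluoromethyl on an aromatic carbon. For the measured compounds named here, the one measured step that bears on this place is the exchange of the group on that ring, a 1.3-fold higher number from compound 1 to compound 2 (0.11 log units; within the scatter), which did not move the number beyond the scatter. A further exchange in the same place is therefore expected to leave the number about where it is, and the expected step from compound 2 to compound 4 is a 1.2-fold lower number from compound 2 to compound 4 (0.07 log units; within the scatter). Compound 4 is expected to give 10000 nM, within a range from 4000 nM to 25000 nM.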

Compound 4, half-maximal inhibitory concentration: 9500 nM
For compound 4 the middle estimate is 1.1-fold (0.02 log units) above the measured one; measured number inside the range.
By their numbers in this assay, from the lowest: compounds 3, 1, 4 and 2 (each within the scatter of the next).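

With methyl on this aromatic carbon, the exchange of trifluoromethyl for methyl gives a 1.2-fold lower number from compound 2 to compound 4 (0.09 log units; within the scatter) in this assay, and the exchange of methoxy for methyl gives a 1.1-fold higher number from compound 1 to compound 4 (0.02 log units; within the scatter). For the compounds shown here, the earlier compounds offered only one comparison at this position, methoxy against trifluoromethyl, whereas three groups can now be compared on the same chain and the same shared core, and every pair among compounds 1, 2 and 4 lies within the scatter, so these three groups cannot be told apart on this read-out. No supporting measurement is available to explain this lack of separation.

The compounds shown leave open whether a group of another kind on this carbon, such as an amine or a carboxylic acid, would move the number beyond the scatter. They also leave open whether a longer chain between the sulfonamide and the shared core would do so, since the only chain exchange shown, in compound 3, carries trifluoromethyl on the ring and its number stays within the scatter of compound 2.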